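The compounds below may be only part of what the source reports. "The series", "measured", "known", "first", "only" and "open" are said of these compounds alone.

Measured in a functional assay on Ehrlich cells (Mus musculus) for antiproliferative activity, read by trypan blue exclusion, with a stated time of 2 h, tested at 10 ug/mL (on this read-out lower numbers stand for a weaker effect and higher numbers for a stronger effect at the one concentration tested), so far:

compound 1, `N#CC1=C(N)N(c2ccc(S(N)(=O)=O)cc2)C2=C(C(=O)CCC2)C1c1ccccc1`: 10%
compound 2, `Cc1ccc(C2C(C#N)=C(N)N(c3ccc(S(N)(=O)=O)cc3)C3=C2C(=O)CCC3)cc1`: 30%
compound 3, `N#CC1=C(N)N(c2ccc(S(N)(=O)=O)cc2)C2=C(C(=O)CCC2)C1c1ccco1`: 0%

Compounds 1 and 2 share the same core and differ only by methyl in place of hydrogen on an aromatic carbon. In this assay the step is a number 20 percentage points higher from compound 1 to compound 2 (beyond the scatter). Compound 3 carries a different group on the saturated ring carbon; the step of a number 10 percentage points lower from compound 1 to compound 3 (within the scatter) is within the scatter, so the two values are not ordered. The step of a number 30 percentage points lower from compound 2 to compound 3 (beyond the scatter) is the larger of the three gaps.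

Compound 4, `Cc1ccoc1C1C(C#N)=C(N)N(c2ccc(S(N)(=O)=O)cc2)C2=C1C(=O)CCC2`, is not yet measured. It differs from compound 3 by methyl in place of hydrogen on an aromatic carbon. Its core differs from the core of compound 1 by furan-2-yl in place of phenyl on a saturated ring carbon. The change from compound 3 to compound 4 is the same kind of change as that from compound 1 to compound 2, but the place is not the same: in compound 2 the methyl sits on an aromatic carbon of a six-membered aromatic ring of carbon only, para to a large group, whereas in compound 4 it sits on an aromatic carbon of a five-membered aromatic ring with one oxygen, next to the ring atom that bears a large group, two ring bonds from the ring oxygen.

For compound 4 a step of a number 10 percentage points higher from compound 3 to compound 4 (within the scatter) in this assay is expected. Going by the values given here, that expectation rests on the single measured instance of this kind of change, a number 20 percentage points higher from compound 1 to compound 2 (beyond the scatter), tempered because the place differs and only one pair is available. Compound 4 is therefore estimated at 10% in this assay, with a range from 0% to 30%.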

Compound 4, a percentage reported as activity, at one concentration (the size of the read-out at that concentration, not a potency): 2%
For compound 4 the middle estimate is 8 percentage points above the measured one; the range from low to high includes it.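

Carrying the methyl-for-hydrogen change from one core to another in this series does not give the same result in this assay: the same change on two cores in this assay, a number 20 percentage points higher (beyond the scatter) from compound 1 to compound 2 and a number 2 percentage points higher (within the scatter) from compound 3 to compound 4, 18 percentage points apart, beyond the scatter of two such steps

On the furan-2-yl core the new step is a number 2 percentage points higher from compound 3 to compound 4 (within the scatter), so the change gives no ordered gain there, and 3-methylfuran-2-yl and phenyl cannot be told apart on the evidence of a number 8 percentage points lower from compound 1 to compound 4 (within the scatter), whereas a number 28 percentage points lower from compound 2 to compound 4 (beyond the scatter) keeps 4-methylphenyl clearly ahead of 3-methylfuran-2-yl. Going by these compounds alone, this does not show why the two steps part: the ring that carries the methyl and the place of the methyl on that ring both differ between the two pairs, with only one pair for each, so the two cannot be separated and no general rule for the series follows.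

The compounds shown leave open whether ethyl, methoxy or chlorine in place of the methyl would follow the phenyl pair or the furan pair. Also open, as far as these compounds go, is what a carboxylic acid in place of the sulfonamide, or an amine on the aromatic ring at the saturated ring carbon, would do to the read-out at the one concentration tested.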